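The source may report more compounds than this note shows. Statements on the series, on what has been measured and on what is new or still open speak of the compounds shown alone.

Working notes on the series. In a physicochemical assay for solubility, with a stated time of 24 h, at pH 6.8 (a higher number here means a more soluble compound, a lower number a less soluble compound), compound 2 `O=C(NC[C@@H]1[C@H]2CN(C(=O)C3CC3c3cc(Cl)cc(Cl)c3)C[C@@H]12)c1ccc2[nH]c(=O)oc2c1` gives < 1 ug/mL, which is a limit and not a number. Compound 1 `O=C(NC[C@@H]1[C@H]2CN(C(=O)OCc3cc(Cl)cc(Cl)c3)C[C@@H]12)c1ccc2[nH]c(=O)oc2c1` gives < 1 ug/mL, also a limit. Compound 3 `O=C(NC[C@@H]1[C@H]2CN(C(=O)N3CCc4c(Cl)cc(Cl)cc4C3)C[C@@H]12)c1ccc2[nH]c(=O)oc2c1` gives < 1 ug/mL, again a limit. The position of compound 2 therefore cannot be ranked against either of the others.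

Next in line is compound 4 `Cc1ccc(COC(=O)N2C[C@@H]3[C@@H](CNC(=O)c4ccc5[nH]c(=O)oc5c4)[C@@H]3C2)nc1`, and the change from compound 2 is a group of 9 heavy atoms (7 carbon, 1 nitrogen, 1 oxygen; one six-membered aromatic ring with 1 hetero atom) in place of a group of 11 heavy atoms (9 carbon, 2 chlorine; one three-membered non-aromatic ring of carbon only, one six-membered aromatic ring of carbon only), on a carbonyl carbon. Among the compounds with values here, the one measured step at this carbonyl carbon is a step that the two limits leave unreadable from compound 1 to compound 2, so it gives no size to carry over. The measured evidence comes down to the limit of < 1 ug/mL in this assay, at which 3 of the 3 values shown sit. Compound 4 differs from all three measured compounds in that its entering group holds no chlorine and has a six-membered aromatic ring with 1 hetero atom. How this assay responds to that difference has not been measured.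

With the limit of < 1 ug/mL in this assay, at which 3 of the 3 values shown sit, any change that can be read as a number has to be upward, and a modest upward move is the working expectation, though a further limit remains quite possible. The expected change is an at least 4.0-fold higher number from compound 2 to compound 4 (0.60 log units; beyond the scatter), an estimate with wide uncertainty. For compound 4 the estimated value is 4 ug/mL, with an expected range of 1 ug/mL to 25 ug/mL.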

Compound 4, solubility: 56 ug/mL
The estimate for compound 4 lay 14-fold (1.15 log units) below the measured number, outside the stated range (above it).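

In this assay, the group on this carbonyl carbon can move the read-out off the limit, which compounds 1, 2 and 3 could not show, and the change gives an at least 56-fold higher number from compound 2 to compound 4 (1.74 log units; beyond the scatter). Within the data shown here, with 5-methylpyridin-2-yl in place of 3,5-dichlorophenyl on a saturated chain carbon bound to an oxygen next to a carbonyl group, the single change in the aryl group gives an at least 56-fold higher number from compound 1 to compound 4 (1.74 log units; beyond the scatter), so a replacement at that carbon alone is enough for a step of this size. Both steps start from a limit, so each gives only a minimum size, and no real starting number exists for either of them because the read-out of the other compounds stops at the same point: the limit of < 1 ug/mL in this assay, at which 3 of the 4 values shown sit.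

The shown compounds do not separate the removal of the two chlorines from the ring nitrogen or the methyl, all of which change together in compound 4. Also open, as far as these compounds go, is whether an unsubstituted pyridin-2-yl, a plain phenyl, or a group carrying an amine such as morpholine at this carbon would hold a readable number in this assay.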